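The source may report more compounds than this note shows. Statements on the series, on what has been measured and on what is new or still open speak of the compounds shown alone.

Of the compounds shown here, three sharing one core have been tested in a functional assay on the whole organism for inhibition, with Rattus norvegicus as the target, read by paw edema, at a dose of 100 mg/kg by the oral route; a lower number here means less inhibition, a higher number more inhibition at the dose given (going by the name of the read-out). Compound 1 `CN(C)CCNC(=O)c1c(O)c2cccnc2n(-c2ccccc2)c1=O` gives 22.6% in this assay. Compound 2 `O=C(NC1CCN(Cc2ccccc2)CC1)c1c(O)c2cccnc2n(-c2ccccc2)c1=O` gives 1.7%. Compound 3 `Nc1ccc(NC(=O)c2c(O)c3cccnc3n(-c3ccccc3)c2=O)cc1` gives -5.5%, the lowest of the three numbers; it lies within the scatter of compound 2 and well apart from compound 1. The one step on record among these three, a number 28.1 percentage points lower from compound 1 to compound 3 (beyond the scatter), shows that exchanging the 2-(dimethylamino)ethyl chain for an aromatic ring on the amide-type nitrogen lowers the read-out by a modest amount.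

The next compound, compound 4 `O=C(Nc1cnccn1)c1c(O)c2cccnc2n(-c2ccccc2)c1=O`, differs from compound 3 in one place: pyrazin-2-yl in place of 4-aminophenyl on an amide-type nitrogen. Going by the values given here, no measured step covers this exchange of one aromatic ring for another on the amide-type nitrogen. The only bearing comes from the two aryl and piperidinyl amides, compounds 2 and 3, whose values sit close to one another near zero inhibition, while the aminoalkyl amide compound 1 stands higher.

Compound 4 is therefore expected to stay in the same low region, with an estimated step of a number 8.5 percentage points higher from compound 3 to compound 4 (within the scatter) that lies within the scatter. The estimate for compound 4 in this assay is 3%, with a range from -15% to 25%.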

Compound 4, a percentage reported as inhibition, in the whole organism at one dose (the size of the read-out at that dose, not a potency): 29.6%
The estimate for compound 4 lay 26.6 percentage points below the measured number; measured number outside the range, above it.
By their numbers in this assay, from the lowest: compounds 3 and 2 (each within the scatter of the next); then compounds 1 and 4 (each within the scatter of the next).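

In this assay, going by these compounds alone, the exchange on the amide-type nitrogen gives a number 35.1 percentage points higher from compound 3 to compound 4 (beyond the scatter) and so shows that one six-membered aromatic ring in place of another can by itself move the read-out by a large amount, which the earlier compounds could not show. Within the data shown here, the exchange of the 2-(dimethylamino)ethyl chain for pyrazin-2-yl at this same place gives a number 7 percentage points higher from compound 1 to compound 4 (within the scatter) and so shows that an aromatic ring on this nitrogen is not tied to the low end of the read-out, and that the chain of compound 1 is not the only group here that reaches this level. No measurement on hand accounts for the difference between compound 3 and compound 4.

Compound 4 differs from compound 3 both by the nitrogens in its ring and by the loss of the amine, and a plain phenyl or a pyridin-2-yl on the same nitrogen would help tell these two changes apart. With only one oral dose in view, it also stays open whether the order of these compounds would hold at other doses.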